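This account rests on a few compounds, and the source may have more. Where it says the series, first, only, none or still open, it means among the compounds named here.

In a functional assay on MCF7 cells (Homo sapiens) for inhibition, read by sulforhodamine B assay (a lower number here means a stronger inhibitor, a higher number a weaker inhibitor), compound 1 `O=C1C(NC2CCCC2)=CC(=O)c2c1nc1n2[C@H]2OC[C@@H](O)[C@H]2OC1` reads > 16000 nM, which is a limit of the assay and not a number. For the measured compounds named here, compound 2 `COc1cccc(NC2=CC(=O)c3c(nc4n3[C@H]3OC[C@@H](O)[C@H]3OC4)C2=O)c1` gives 3830 nM, the only true number so far. Going by the values given here, the single measured step, an at least 4.1-fold lower number from compound 1 to compound 2 (0.62 log units; beyond the scatter), put 3-methoxyphenyl in place of cyclopentyl on an amine nitrogen and starts from the limit of > 16000 nM in this assay, at which 1 of the 2 values shown sits. Compound 3 `O=C1C(Nc2cccc(F)c2)=CC(=O)c2c1nc1n2[C@H]2OC[C@@H](O)[C@H]2OC1` has fluoro in place of methoxy on an aromatic carbon. That measured step did not vary this substituent, so no change beyond the scatter is expected in this assay. The expected step is a 1.0-fold lower number from compound 2 to compound 3 (0.00 log units; within the scatter). Compound 3 is estimated at 3800 nM, within an expected range of 1500 nM to 10000 nM.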

Compound 3, half-maximal inhibitory concentration: > 4000 nM
Compound 3: only a limit was reported; the forecaster's own chance of this, stated with the estimate: 10%; middle value at least 1.0-fold (0.02 log units) away from the limit.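

In this assay compound 3 gives > 4000 nM, which is a limit and not a number. This is the first change shown on the aromatic ring itself, and fluoro in place of methoxy gives an at least 1.0-fold higher number from compound 2 to compound 3 (0.01 log units; that floor lies within the scatter), so the data cannot tell whether the swap moves the number beyond the scatter or not at all. The step between compound 1 and compound 3 cannot be read, as both values are limits.

Going by these compounds, the true value of compound 3 remains open. So does how chloro or an amine would read on this aromatic carbon.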